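Amino for Cyano on the Side Chain of Compound 2

The compounds below may be only part of what the source reports. "The series", "measured", "known", "first", "only" and "open" are said of these compounds alone.

Measured so far:
compound 1 `N#CCCCc1c[nH]c2ccc(F)cc12`, 72 nM
compound 2 `N#CCCCc1c[nH]c2ccc(C(=O)O)cc12`, "not active" (no number reported)

In an assay on isolated protein for inhibition of Myeloperoxidase (Homo sapiens), read by ELISA, with a stated time of 5 min (on this read-out lower numbers stand for stronger inhibition and higher numbers for weaker inhibition), compound 1 gives 72 nM. Compound 2, whose structure is `N#CCCCc1c[nH]c2ccc(C(=O)O)cc12`, is reported in this assay as "not active" (no number reported), so no single number marks where it stands; it can only be said that compound 2 failed to show the inhibition that compound 1 showed. Compound 3, `NCCCc1c[nH]c2ccc(C(=O)O)cc12`, has not yet been tested. It differs from compound 2 in one place: amino in place of cyano on a saturated chain carbon, three bonds along the chain from an aromatic carbon. Without a measured step of this kind among the compounds shown, and with compound 2 giving no number to build on, no clear direction can be read off; a small gain toward measurable inhibition is possible, as is no change beyond the scatter. For compound 3 the estimate in this assay is 10000 nM, with a range from 1000 nM to 100000 nM.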

Compound 3, half-maximal inhibitory concentration: "not active" (no number reported)
Compound 3: no number reported; the estimate stays without a comparison.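

Going by these compounds alone, compound 2 and compound 3 are both reported without a number, so no step between them can be read. The compounds shown leave open whether amino in place of cyano changes inhibition when the starting compound has a measurable value, as compound 1 does. No measured evidence shown here bears on this result.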